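From ethenyl to ethyl on compound 3

This account rests on a few compounds, and the source may have more. Where it says the series, first, only, none or still open, it means among the compounds named here.

Results so far in an ADME assay on Vero cells (Chlorocebus sabaeus) for cytotoxicity, read by MTT assay, with a stated time of 72 h (a higher number here means that more compound is tolerated, a lower number that less compound is tolerated), are these:
- compound 1 `CC(C)=CCCC1(C)C=Cc2c(ccc(C(=O)/C=C/c3ccc(O)c(C=O)c3)c2O)O1` gives "not determined" (no result reported) 
- compound 2 `CC(C)=CCCC1(C)C=Cc2c(ccc(C(=O)/C=C/c3ccc4occc4c3)c2O)O1` gives "not determined" (no result reported) 
- compound 3 `CC(C)=CCCC1(C)C=Cc2c(ccc(C(=O)/C=C/c3cccnc3)c2O)O1` gives 40700 nM 

Of these three compounds, only compound 3 has a number, so it cannot be ranked against the other two. For the measured compounds named here, compound 1 and compound 2 have no result, and no pair of measured compounds shows what a single change does.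

The next compound is compound 4 `CC(C)=CCCC1(C)C=Cc2c(ccc(C(=O)CCc3cccnc3)c2O)O1` which differs from compound 3 at one place. It carries 2-(pyridin-3-yl)ethyl in place of 2-(pyridin-3-yl)ethenyl on a carbonyl carbon. The ring and the count of heavy atoms in this group stay the same, and the double bond outside aromatic rings is lost.

With compound 3 at 40700 nM as the only anchor, any expectation here is loose. The expected step of a 1.5-fold higher number from compound 3 to compound 4 (0.17 log units; within the scatter) is modest, pointing towards more compound tolerated in this assay and possibly staying within the usual scatter. Compound 4 is estimated at 60000 nM with 22000 nM to 160000 nM as the expected range.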

Compound 4, half-maximal cytotoxic concentration: 266000 nM
The estimate for compound 4 lay 4.4-fold (0.65 log units) below the measured number, outside the stated range (above it).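

In this assay, for the compounds shown here, the first readable step lies on the carbonyl carbon: a 6.5-fold higher number from compound 3 to compound 4 (0.82 log units; beyond the scatter) and this step is beyond the usual scatter. The ring and the count of heavy atoms in the group stay the same, so the loss of the double bond outside aromatic rings is the only difference between the two compounds, and that single change is enough to move this read-out towards more compound tolerated. Nothing measured here says why the number rises.

Going by these compounds alone, compound 1 and compound 2 have no number, so no step involving them can be read, and it remains open whether the same change would raise the number with anything other than the pyridin-3-yl ring at the end of the group. Within the data shown here, also open is how the read-out would respond to a longer chain between the carbonyl carbon and the pyridin-3-yl ring, or to an amine on that chain, since compound 3 and compound 4 show only one pair at this position.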